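The source may report more compounds than this note shows. Statements on the series, on what has been measured and on what is new or still open speak of the compounds shown alone.

Series notes. Compound 1 `Nc1nc(N/N=C/c2ccc(-c3ccc(Br)cc3)o2)nc2c1ncn2[C@@H]1O[C@H](CO)[C@@H](O)[C@H]1O` and compound 2 `Nc1nc(N/N=C/c2cccnc2Cl)nc2c1ncn2[C@@H]1O[C@H](CO)[C@@H](O)[C@H]1O` share one core and differ only in the group on the carbon with a double bond to nitrogen. In an assay on CHO-K1 cells for displacement of a labelled ligand from adenosine receptor A1 (Homo sapiens), read by scintillation counting, with a stated time of 60 min (on this read-out higher numbers stand for weaker inhibition and lower numbers for stronger inhibition), compound 1 gives 4.5 nM. In this assay compound 2 gives 4.6 nM; of the two numbers shown it is the larger, but the gap to compound 1 is within the scatter, so no order between the two is claimed. Compound 3 `COc1cc(/C=N/Nc2nc(N)c3ncn([C@@H]4O[C@H](CO)[C@@H](O)[C@H]4O)c3n2)cc(OC)c1OC` in this assay gives > 10000 nM, which is the limit of > 10000 nM in this assay, at which 1 of the 3 values shown sits, and not a number. Compound 4 `Nc1nc(N/N=C/c2ccc(C(F)(F)F)cc2)nc2c1ncn2[C@@H]1O[C@H](CO)[C@@H](O)[C@H]1O` has not yet been measured in this assay. Against compound 2 it carries 4-(trifluoromethyl)phenyl in place of 2-chloropyridin-3-yl on a carbon with a double bond to nitrogen. For the measured compounds named here, no step between measured compounds is available, so the size of this change is not fixed by the data; the expectation for this assay is a small loss, near the edge of the scatter, from compound 2 to compound 4. Compound 4 is expected to give about 10 nM in this assay, within a range from 2.5 nM to 60 nM. The expected step is a 2.2-fold higher number from compound 2 to compound 4 (0.34 log units; beyond the scatter).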

Compound 4, inhibition constant: 37 nM
Compound 4: the middle estimate sits 3.7-fold (0.57 log units) below what was measured; low and high end bracket the measured number.
By their numbers in this assay, from the lowest: compounds 1 and 2 (each within the scatter of the next); then compound 4. At a limit, above all of these: compound 3.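

In this assay, for the compounds shown here, the change to 4-(trifluoromethyl)phenyl from 2-chloropyridin-3-yl on a carbon with a double bond to nitrogen gives an 8.0-fold higher number from compound 2 to compound 4 (0.91 log units; beyond the scatter) and is the first step that can be read at this place. A six-membered aromatic ring of carbon only, in a group with no hydrogen-bond acceptor, still leaves compound 4 with a measured number, so neither the ring nitrogen nor the chlorine of compound 2 is needed for one, though the step is beyond the scatter. Compound 3, also with a single aromatic ring at this place, stands at a limit and not at a number: the limit of > 10000 nM in this assay, at which 1 of the 4 values shown sits.

From the compounds shown here alone, whether the step follows the trifluoromethyl group or the loss of the ring nitrogen and chlorine stays open, and a plain phenyl, or a phenyl carrying an amine or a carboxylic acid, would bear on this. The compounds shown give no cause for the step.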